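Fluoro for Cyano on the Anilino Ring of Compound 2

The source may hold more compounds than are shown below. What is called first, only, known or untested is meant among the compounds shown, and "the series" means these compounds.

Compound 2 `N#Cc1ccc(Nc2ncnc3c(=N)n(NC(=O)c4ccncc4)cnc23)cc1` has no single number in an ADME assay on Vero cells (Chlorocebus sabaeus) for cytotoxicity; on this read-out higher numbers stand for an effect only at larger amounts of compound and lower numbers for an effect already at smaller amounts; for compound 2 the record shows "not determined" (no result reported). Its relative compound 1 `N=c1c2ncnc(Nc3ccccc3)c2ncn1NC(=O)c1ccncc1`, which carries a plain phenyl ring, gives 4.37 ug/mL in this assay. Compound 3 `N=c1c2ncnc(Nc3ccc(F)cc3)c2ncn1NC(=O)c1ccncc1` differs from compound 2 by fluoro in place of cyano on an aromatic carbon. For the measured compounds named here, with no measured step between these two compounds, nothing beyond the usual scatter is expected for compound 3 relative to where compound 1 stands. Compound 3 is therefore estimated at 5 ug/mL in this assay, within a range from 1.5 ug/mL to 15 ug/mL.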

Compound 3, half-maximal effective concentration: 1.53 ug/mL
Compound 3: the middle estimate sits 3.3-fold (0.51 log units) above what was measured; measured number inside the range.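

Fluoro on this aromatic carbon gives a 2.9-fold lower number from compound 1 to compound 3 (0.46 log units; beyond the scatter) in this assay, so this place on the ring can move the read-out, toward an effect at smaller amounts of compound. The step from compound 2 to compound 3 cannot be read, since compound 2 has no number. No measurement at hand accounts for the shift.

Where the cyano of compound 2 would stand on this read-out remains open. So does whether a methoxy group or an amine at this place would lower the number as fluoro does.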